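A few compounds are considered here, and "the series" means these few. Any claim that something is new, unique, unknown or untested is made for them only; others in the source may bear on it.

Compound 2, `CNC(=O)c1cc(Oc2ccc3nc(NC(=O)Nc4ccc(Cl)cc4)sc3c2)ccn1`, is the more active of the two compounds measured in a functional assay on HCT-116 cells (Homo sapiens) for inhibition, read by MTT assay, with a stated time of 2 days, tested at 100 uM; a higher number here means more inhibition of growth at the concentration tested, a lower number less inhibition of growth: compound 2 gives 85.2%, while compound 1, `CNC(=O)c1cc(Oc2ccc3nc(NC(=O)c4cc(Cl)cc(Cl)c4)sc3c2)ccn1`, gives 15.8%. Compound 3, `CNC(=O)c1cc(Oc2ccc3nc(NC(=O)Nc4ccc(N5CCN(C)CC5)cc4)sc3c2)ccn1`, differs from compound 2 by 4-methylpiperazin-1-yl in place of chloro on an aromatic carbon. Within the data shown here, the only measured step, a number 69.4 percentage points higher from compound 1 to compound 2 (beyond the scatter), alters a different part of the molecule and so does not bear directly on this change; no measured step tests the swap of chloro for 4-methylpiperazin-1-yl. The expectation for compound 3 is therefore uncertain, with a moderate decrease of a number 20.2 percentage points lower from compound 2 to compound 3 (beyond the scatter) estimated. Compound 3 is expected at 65%, within 30% to 90%.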

Compound 3, percent growth inhibition at one concentration: 95%
For compound 3 the middle estimate is 30 percentage points below the measured one; the measured number lies above the stated range.
By their numbers in this assay, from the lowest: compound 1; then compounds 2 and 3 (each within the scatter of the next).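

In this assay, 4-methylpiperazin-1-yl in place of chloro gives a number 9.8 percentage points higher from compound 2 to compound 3 (within the scatter). This shows that, on this aromatic carbon, a single chlorine atom can give way to a group with a six-membered non-aromatic ring without a change beyond the scatter. No available data give a reason for this result. The compounds shown leave open whether a small amine such as dimethylamino, or a carboxylic acid, would read the same way on this carbon. From the compounds shown here alone, how compound 2 and compound 3 compare at lower concentrations also remains open.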